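From Chloro to Methoxy: What to Expect for Compound 4

The source may report more compounds than this note shows. Statements on the series, on what has been measured and on what is new or still open speak of the compounds shown alone.

Of the compounds shown here, three sharing one core have been measured in a functional assay on SW480 cells (Homo sapiens) for inhibition, read by MTT assay, with a stated time of 72 h; a higher number here means a weaker inhibitor of growth, a lower number a stronger inhibitor of growth. Compound 1 `N#C/C(=C\c1ccco1)C(=O)NCc1ccc(Cl)c(Cl)c1` carries a furan-2-yl group on a double-bonded chain carbon; in this assay compound 1 gives > 50000 nM, which is a limit of the assay rather than a number (the limit of > 50000 nM in this assay, at which 1 of the 3 values shown sits). Compound 2 `N#C/C(=C\c1ccccc1)C(=O)NCc1ccc(Cl)c(Cl)c1` has a phenyl group there instead, and in this assay compound 2 gives 49000 nM. Compound 3 `N#C/C(=C\c1ccc(Cl)cc1)C(=O)NCc1ccc(Cl)c(Cl)c1` has a 4-chlorophenyl group, and in this assay compound 3 gives 30000 nM, the lower of the two numbers shown, though the step of a 1.6-fold lower number from compound 2 to compound 3 (0.21 log units; within the scatter) lies within the scatter. The steps of an at least 1.0-fold lower number from compound 1 to compound 2 (0.00 log units; that floor lies within the scatter) and an at least 1.6-fold lower number from compound 1 to compound 3 (0.22 log units; that floor lies within the scatter) start from a limit and so only set floors.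

Compound 4 `COc1ccc(/C=C(\C#N)C(=O)NCc2ccc(Cl)c(Cl)c2)cc1` has not yet been measured. It differs from compound 3 by methoxy in place of chloro on an aromatic carbon. Within the data shown here, the only measured step at this aromatic carbon is the change from hydrogen to chloro, a 1.6-fold lower number from compound 2 to compound 3 (0.21 log units; within the scatter), which did not rise above the scatter. Nothing measured here shows what a methoxy does in this place, so no step beyond the scatter is expected. For compound 4 the estimate is 35000 nM, with a range from 15000 nM to 80000 nM. The expected step of a 1.2-fold higher number from compound 3 to compound 4 (0.07 log units; within the scatter) is therefore small and within the scatter.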

Compound 4, concentration for 50% growth inhibition: 95000 nM
For compound 4 the middle estimate is 2.7-fold (0.43 log units) below the measured one; measured number above the stated range.
By their numbers in this assay, from the lowest: compounds 3, 2 and 4 (each within the scatter of the next, the first and the last beyond it).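

Among these compounds, this is the first change at this aromatic carbon, para to a large group, that clears the scatter in this assay (a 3.2-fold higher number from compound 3 to compound 4 (0.50 log units; beyond the scatter)), so the choice between chloro and methoxy here does register in the growth read-out. Against the plain hydrogen of compound 2 the picture is less sharp (a 1.9-fold higher number from compound 2 to compound 4 (0.29 log units; within the scatter)), and the earlier step from hydrogen to chloro was also within the scatter, so compound 3 and compound 4 can be told apart from each other but neither can be told apart from compound 2. The step that starts from compound 1 cannot be read, since the value of compound 1 is a limit of the assay and not a number: the limit of > 50000 nM in this assay, at which 1 of the 4 values shown sits.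

The compounds shown give only three groups at this carbon, so it stays open whether the gap between chloro and methoxy extends to others such as bromo, an amine, a carboxylic acid or a longer chain like ethoxy. They also do not tell why methoxy and chloro differ here, or whether the same swap would give a step of this size elsewhere on the shared core.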